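This account rests on a few compounds, and the source may have more. Where it says the series, first, only, none or still open, it means among the compounds named here.

Compound 1 `Cc1cc(Cl)ccc1Nc1ncc(C(F)(F)F)c(N2Cc3cccc(N(C)S(C)(=O)=O)c3C2)n1` gives 19600 nM in a functional assay on HepG2 cells (Homo sapiens) for antiproliferative activity, read by spectrophotometry, with a stated time of 2 days; a higher number here means a weaker inhibitor of growth, a lower number a stronger inhibitor of growth.
Compound 2 `CN(c1cccc2c1CN(c1nc(Nc3ccc(C(F)(F)F)cc3)ncc1C(F)(F)F)C2)S(C)(=O)=O` gives > 30000 nM in this assay, which is a limit of the assay and not a number.
Compound 3 `Cc1ccc(Nc2ncc(C(F)(F)F)c(N3Cc4cccc(N(C)S(C)(=O)=O)c4C3)n2)c(Cl)c1` gives > 30000 nM in this assay, again a limit of the assay.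

Compound 2 thus stands at the upper edge of what this assay can report, and it shares that position with one other compound, as the limit of > 30000 nM in this assay, at which 2 of the 3 values shown sit, records. Only compound 1 returns a finite number. The measured steps all change the aryl group on the nitrogen: an at least 1.5-fold higher number from compound 1 to compound 2 (0.18 log units; that floor lies within the scatter), an at least 1.5-fold higher number from compound 1 to compound 3 (0.18 log units; that floor lies within the scatter), and a step that the two limits leave unreadable from compound 2 to compound 3. The step to compound 4 `CC(=O)N1CCN(c2ccc(Nc3ncc(C(F)(F)F)c(N4Cc5cccc(N(C)S(C)(=O)=O)c5C4)n3)cc2)CC1` is different in kind: 4-acetylpiperazin-1-yl in place of trifluoromethyl on an aromatic carbon. Within the data shown here, none of the measured steps touches this kind of change, and two of them end at a limit, so they set no size for it. The account therefore rests on a weak expectation that compound 4 may reach a finite number, with a step of about an at least 2.0-fold lower number from compound 2 to compound 4 (0.30 log units; that floor lies within the scatter) expected from compound 2. Compound 4 is estimated at 15000 nM, with a range from 3000 nM to 40000 nM.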

Compound 4, concentration for 50% growth inhibition: 1400 nM
Beside the measured number, compound 4's estimate is 11-fold (1.03 log units) above it; measured number below the stated range.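

Replacing trifluoromethyl with 4-acetylpiperazin-1-yl on an aromatic carbon, para to a large group, gives an at least 21-fold lower number from compound 2 to compound 4 (1.33 log units; beyond the scatter) in this assay, the first step among these compounds that lies beyond the scatter. This position therefore accepts a much larger group bearing a six-membered non-aromatic ring, and the change moves the result from a limit of the assay to a finite number. The size of the step is only a floor, since compound 2 stands at a limit of the assay: the limit of > 30000 nM in this assay, at which 2 of the 4 values shown sit.

The compounds shown do not separate the ring of 4-acetylpiperazin-1-yl from its acetyl, so a piperazine with a free amine or a morpholine at this place could show which part carries the step. They also leave open whether a carboxylic acid or a longer chain ending in an amine would give a similar step here.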